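Swapping the Carbonyl Group on Compound 2

The source may hold more compounds than are shown below. What is called first, only, known or untested is meant among the compounds shown, and "the series" means these compounds.

Compound 2 `O=C(N1CCC(c2nc(-c3ccc4ccccc4n3)no2)CC1)N1CCCc2ccccc21` is the starting point here. In a functional assay on Shh Light II cells (Mus musculus) for inhibition, read by a luciferase reporter (a higher number here means a weaker inhibitor, a lower number a stronger inhibitor), compound 2 gives 2300 nM. That sits within the usual scatter of the other two measured compounds: compound 1 `O=C(NC1CCNCC1)N1CCC(c2nc(-c3ccc4ccccc4n3)no2)CC1` gives 2500 nM and compound 3 `COc1ccccc1NC(=O)N1CCC(c2noc(-c3ccc4ccccc4n3)n2)CC1` gives 2400 nM. Among the compounds with values here, no measured compound therefore stands apart from the rest.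

The next compound, compound 4 `O=C(OC1CCCCC1)N1CCC(c2nc(-c3ccc4ccccc4n3)no2)CC1`, carries cyclohexyloxy in place of 1,2,3,4-tetrahydroquinolin-1-yl on a carbonyl carbon.

Within the data shown here, only one measured step bears on this change. At the same carbonyl carbon, 1,2,3,4-tetrahydroquinolin-1-yl in place of (piperidin-4-yl)amino gave a 1.1-fold lower number from compound 1 to compound 2 (0.04 log units; within the scatter). That single pair hints that the number may tolerate a change of group at this place, but one pair is thin evidence. Among the measured compounds shown here, none of the measured compounds has cyclohexyloxy or any other oxygen-linked group on this carbon, so the new group is untested.

No change beyond the scatter is therefore expected, in either direction, and the estimated step is no change at the digits printed from compound 2 to compound 4 (within the scatter). The estimate for compound 4 in this assay is 2300 nM, with an expected range from 800 nM to 6500 nM.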

Compound 4, half-maximal inhibitory concentration: 580 nM
Beside the measured number, compound 4's estimate is 4.0-fold (0.60 log units) above it; the whole stated range lies above it.
By their numbers in this assay, from the lowest: compound 4; then compounds 2, 3 and 1 (each within the scatter of the next).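

The group on this carbonyl carbon does affect the number in this assay. Within the data shown here, the one earlier step at this place stayed within the scatter, whereas cyclohexyloxy in place of 1,2,3,4-tetrahydroquinolin-1-yl gives a 4.0-fold lower number from compound 2 to compound 4 (0.60 log units; beyond the scatter), and cyclohexyloxy in place of (piperidin-4-yl)amino gives a 4.3-fold lower number from compound 1 to compound 4 (0.63 log units; beyond the scatter). Among these compounds, two nitrogen-linked groups thus sit within the scatter of each other, while the single oxygen-linked group, cyclohexyloxy, stands apart from both with the lower number. No available evidence accounts for this shift, so the data cannot tell whether the linking oxygen or the ring of carbon only is what counts.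

A cyclohexylamino group on this carbon would keep the ring of carbon only while replacing the oxygen link with a nitrogen link, which would separate those two features. A phenoxy group or a short ethoxy chain would show how much the ring itself can change, and the compounds shown leave both questions open.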